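The compounds below may be only part of what the source reports. "The series", "measured", "known", "first", "only" and "open" are said of these compounds alone.

For the measured compounds named here, compound 1 `N#Cc1cccc([C@]23CCC(N(CCN4CC[C@@H](O)C4)C(=O)Nc4cccc(Br)c4)CC2C3)c1` has the lower of the two numbers measured so far in a functional assay for antagonist activity at melanin-concentrating hormone receptor 1 (Homo sapiens); on this read-out higher numbers stand for weaker inhibition and lower numbers for stronger inhibition: compound 1 gives 34 nM, whereas compound 2 `N#Cc1cccc(NC(=O)N(CCN2CC[C@@H](O)C2)C2CC[C@]3(c4cccc(C#N)c4)CC3C2)c1` gives 92 nM. The step between them is a 2.7-fold higher number from compound 1 to compound 2 (0.43 log units; beyond the scatter), which concerns only a group on an aromatic ring. Compound 3 `CC(C)N(CCN(C(=O)Nc1cccc(Br)c1)C1CC[C@]2(c3cccc(C#N)c3)CC2C1)C(C)C` differs from compound 1 in a different place: diisopropylamino in place of 3-hydroxypyrrolidin-1-yl on a saturated chain carbon, two bonds along the chain from an amide-type nitrogen. Going by the values given here, the single measured step, that from compound 1 to compound 2, leaves the chain untouched, so no measured step bears on the change that leads to compound 3. The data therefore give no direction for this exchange, and the expectation for compound 3 is a number near that of compound 1, carrying a wide range on both sides. The expected step is a 1.8-fold higher number from compound 1 to compound 3 (0.25 log units; within the scatter). Compound 3 is thus estimated at 60 nM, within a range from 15 nM to 250 nM in this assay.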

Compound 3, inhibition constant: 5.7 nM
Beside the measured number, compound 3's estimate is 11-fold (1.02 log units) above it; the whole stated range lies above it.
By their numbers in this assay, from the lowest: compound 3; then compound 1; then compound 2.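

For the compounds shown here, the chain position turns out to be sensitive to the group it carries: in this assay this exchange gives a 6.0-fold lower number from compound 1 to compound 3 (0.78 log units; beyond the scatter), and it is the only measured change at this end of the molecule. The entering diisopropylamino group has no ring and 0 hydrogen-bond donors, so neither the five-membered ring of 3-hydroxypyrrolidin-1-yl, nor its hydroxy group, nor its defined stereocentre is required for a low number on the core of compound 1. Nothing available explains why the number falls.

As far as these compounds go, this single exchange changes all of these features at once, so their separate contributions stay open; a plain pyrrolidin-1-yl or a diethylamino group at this place would help to tell them apart. Also open, from the compounds shown here alone, is whether diisopropylamino would lower the number to the same extent with the nitrile of compound 2 on the aromatic ring.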